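This account rests on a few compounds, and the source may have more. Where it says the series, first, only, none or still open, it means among the compounds named here.

Measured so far:
compound 1 `O=C(O)Cc1sc(C(c2ccc(F)cc2)c2ccc(F)cc2)nc1-c1cc(F)nc(F)c1` — 110 nM
compound 2 `CN(C)c1cc(-c2nc(C(c3ccc(F)cc3)c3ccc(F)cc3)sc2CC(=O)O)ccn1` — > 100000 nM

Compound 1 `O=C(O)Cc1sc(C(c2ccc(F)cc2)c2ccc(F)cc2)nc1-c1cc(F)nc(F)c1` gives 110 nM in an in vitro functional assay on HEK285-7 cells for antagonist activity at prostaglandin D2 receptor 2 (Homo sapiens), read by BRET and beta-arrestin recruitment; a lower number here means a stronger inhibitor, a higher number a weaker inhibitor. Compound 2 `CN(C)c1cc(-c2nc(C(c3ccc(F)cc3)c3ccc(F)cc3)sc2CC(=O)O)ccn1` in this assay is reported only as a limit of the assay, > 100000 nM; the evidence for that is the limit of > 100000 nM in this assay, at which 1 of the 2 values shown sits. Going by the values given here, the single measured step, an at least 900-fold higher number from compound 1 to compound 2 (2.95 log units; beyond the scatter), is therefore itself only a lower bound, and it tells how far compound 2 stands from compound 1 on the shared core.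

Compound 3 `O=C(O)Cc1sc(C(c2ccc(F)cc2)c2ccc(F)cc2)nc1-c1ccnc(O)c1` is not yet measured. Its difference from compound 2 is hydroxy in place of dimethylamino on an aromatic carbon, on an aromatic carbon of a six-membered aromatic ring with one nitrogen, next to the ring nitrogen. Among the compounds with values here, no measured step touches a hydroxy on that ring, so the only bearing comes from compound 2 sitting at the limit: a return toward compound 1 cannot be excluded, nor can a second limit.

The step from compound 2 to compound 3 is expected as an at least 10-fold lower number from compound 2 to compound 3 (1.00 log units; beyond the scatter) in this assay, in the direction of a lower number. Compound 3 is expected near 10000 nM, within 1000 nM to 100000 nM.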

Compound 3, half-maximal inhibitory concentration: 890 nM
Estimate against measurement, compound 3: 11-fold (1.05 log units) above, outside the stated range (below it).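

A substituent on this carbon that is not fluorine does not by itself abolish activity: in this assay, hydroxy in place of dimethylamino, next to the ring nitrogen, gives an at least 110-fold lower number from compound 2 to compound 3 (2.05 log units; beyond the scatter). The loss seen in compound 2 therefore goes with the dimethylamino group and not with every departure from the 2,6-difluoropyridin-4-yl group, although the size of that recovery stays a bound, as compound 2 is reported only as a limit of the assay: the limit of > 100000 nM in this assay, at which 1 of the 3 values shown sits. Against the difluoro parent, the 2-hydroxypyridin-4-yl group still gives an 8.1-fold higher number from compound 1 to compound 3 (0.91 log units; beyond the scatter), so activity is kept but does not fully return, and this single step cannot separate the exchange of one fluorine for hydroxy from the loss of the other fluorine.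

Open, as far as these compounds go, is whether the sharp drop belongs to nitrogen on this carbon as such or to the two methyl groups, which a primary amine or a methylamino group on the same carbon would help to separate. A methoxy group there, or a pyridine carrying a single fluorine, would show how much of the gap to compound 1 depends on the hydroxy hydrogen and how much on the second fluorine.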